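The source may hold more compounds than are shown below. What is called first, only, known or untested is meant among the compounds shown, and "the series" means these compounds.

In a functional assay on cells (Homo sapiens) for inhibition, read by MTT assay, with a stated time of 48 h (a lower number here means a stronger inhibitor, a higher number a weaker inhibitor), compound 1 `O=C(CCCOc1no[n+]([O-])c1S(=O)(=O)c1ccccc1)NO` gives 22000 nM and compound 2 `CC(C)(COc1no[n+]([O-])c1S(=O)(=O)c1ccccc1)C(=O)NO` gives 18300 nM. For the measured compounds named here, these are the only two numbers so far, and compound 2 stands within the scatter of compound 1, so the two cannot be told apart. Compound 3 `O=C(/C=C/COc1no[n+]([O-])c1S(=O)(=O)c1ccccc1)NO` keeps the shared core and differs from compound 2 in its chain: 2-(hydroxycarbamoyl)ethenyl in place of 1-(hydroxycarbamoyl)-1-methylethyl on a saturated chain carbon bound to an oxygen on an aromatic ring. In short, 2-(hydroxycarbamoyl)ethenyl comes in place of 1-(hydroxycarbamoyl)-1-methylethyl. Going by the values given here, the only measured guide is a change in the same part of the chain, a 1.2-fold lower number from compound 1 to compound 2 (0.08 log units; within the scatter), and it stays within the scatter. Among the compounds with values here, no measured compound carries the 2-(hydroxycarbamoyl)ethenyl group, so this guide is limited, and no shift beyond the scatter is expected. The expected change is a 1.1-fold lower number from compound 2 to compound 3 (0.03 log units; within the scatter). For compound 3 the estimate is 17000 nM, with an expected range of 7000 nM to 40000 nM.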

Compound 3, half-maximal inhibitory concentration: 57700 nM
Compound 3: middle estimate off by 3.4-fold (0.53 log units), on the low side; the whole stated range lies below it.
By their numbers in this assay, from the lowest: compounds 2 and 1 (each within the scatter of the next); then compound 3.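

In this assay, the chain at this place is not indifferent after all: the two saturated chains could not be told apart, but 2-(hydroxycarbamoyl)ethenyl in place of 1-(hydroxycarbamoyl)-1-methylethyl gives a 3.2-fold higher number from compound 2 to compound 3 (0.50 log units; beyond the scatter). In place of 2-(hydroxycarbamoyl)ethyl, the same group gives a 2.6-fold higher number from compound 1 to compound 3 (0.42 log units; beyond the scatter), so compound 3 is the weaker inhibitor against both saturated chains. Nothing measured here bears on why the number rises.

The three chains shown cannot settle whether the double bond in the chain alone accounts for the step, or whether the other differences between the chains also contribute. On these data alone, how a longer chain, or a carboxylic acid in place of the hydroxycarbamoyl group, would read in this assay remains open.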